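Swapping one aryl group on a growth-inhibiting scaffold

The source may hold more compounds than are shown below. What is called first, only, known or untested is meant among the compounds shown, and "the series" means these compounds.

Compound 1 `Cc1ccc(/C=C/C(=O)/C=C(O)/C=C/c2ccc(C)o2)o1`: > 25000 nM (a limit)
Compound 2 `COc1cc(/C=C/C(=O)/C(=C/c2cc(OC)c(OC)c(OC)c2)C(C)=O)cc(OC)c1OC`: 530 nM
Compound 3 `COc1cc(C=C(C(=O)/C=C/c2ccc(OC)c(OC)c2)C(=O)/C=C/c2ccc(OC)c(OC)c2)ccc1O`: 530 nM

These three compounds were tested in a functional assay on A549 cells (Homo sapiens) for inhibition, read by sulforhodamine B assay, with a stated time of 48 h; on this read-out lower numbers stand for stronger inhibition of growth and higher numbers for weaker inhibition of growth. Compound 1 reads > 25000 nM as a limit of the assay and not as a number. Compound 3 gives 530 nM and stands level with compound 2, the nearest value, with no difference beyond the usual scatter.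

Compound 4 `COc1ccc(/C=C/C(=O)C(=Cc2ccc(F)cc2)C(=O)/C=C/c2ccc(OC)c(OC)c2)cc1OC` has not yet been measured. Compared with compound 3, it has 4-fluorophenyl in place of 4-hydroxy-3-methoxyphenyl on a double-bonded chain carbon bound to a double-bonded chain carbon. Going by the values given here, no pair of measured compounds differs in only one place, so the size of this step has no direct precedent. Compound 2 also lacks the 4-hydroxy-3-methoxyphenyl group yet gives 530 nM in this assay, so a large loss seems unlikely. The expected change, a 1.3-fold higher number from compound 3 to compound 4 (0.12 log units; within the scatter), is a slight weakening that stays within the scatter. For compound 4 the estimated value is 700 nM with an expected range from 200 nM to 2500 nM.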

Compound 4, concentration for 50% growth inhibition: 550 nM
The estimate for compound 4 lay 1.3-fold (0.10 log units) above the measured number; low and high end bracket the measured number.
By their numbers in this assay, from the lowest: compounds 2, 3 and 4 (each within the scatter of the next). At a limit, above all of these: compound 1.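

In this assay, putting 4-fluorophenyl in place of 4-hydroxy-3-methoxyphenyl on a double-bonded chain carbon bound to a double-bonded chain carbon gives a 1.0-fold higher number from compound 3 to compound 4 (0.02 log units; within the scatter). Going by these compounds alone, this pair is the first direct reading at this place: a group with 1 hydrogen-bond donor and 2 hydrogen-bond acceptors leaves, one with 0 of each enters, and the number stays within the scatter. In this pair, then, the hydroxy and methoxy groups are not needed to hold growth inhibition at this level, and nothing measured here gives a reason for that result.

From the compounds shown here alone, whether this place accepts a very different group, such as an amine or a carboxylic acid, remains open. Also open, going by these compounds, is whether the other aryl groups on the shared core would tolerate a similar swap.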